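The source may report more compounds than this note shows. Statements on the series, on what has been measured and on what is new or still open speak of the compounds shown alone.

Compound 1 `O=C(O)[C@H](CO)NC(=O)[C@H]1C[C@H](O)CN1` gives in an ADME assay for metabolic stability, read by HPLC, in simulated gastric fluid, with a stated time of 12 h, at pH 1.2 (a higher number here means that the compound lasts longer, a lower number that the compound disappears faster), a limit rather than a number, > 12 h.
Compound 2 `O=C(N[C@H](CO)C(=O)O)[C@@H]1C[C@H](O)CN1` likewise gives only a limit in this assay, > 12 h.
Compound 3 `O=C(O)[C@H](CO)NC(=O)[C@@H]1C[C@H](O)CN1` also gives only a limit in this assay, > 12 h.

Compound 1 therefore stands at the upper limit of this assay, and the two other values shown are the same limit, so that all three values sit together without a readable number between them (the limit of > 12 h in this assay, at which 3 of the 3 values shown sit). The measured steps are correspondingly unreadable: a step that the two limits leave unreadable from compound 1 to compound 2, a step that the two limits leave unreadable from compound 1 to compound 3 and a step that the two limits leave unreadable from compound 2 to compound 3, each resting on a pair that differs only in configuration as drawn the fact that compounds 1 and 2 differ only in the configuration as drawn the fact that compounds 1 and 3 differ only in the configuration as drawn (the fact that compounds 2 and 3 differ only in the configuration as drawn). Compound 4 `O=C(O)[C@H](CO)NC(=O)[C@@H]1C[C@@H](O)CN1` differs from compound 1 in the same way: the two compounds have the same atoms and bonds and differ only in configuration as drawn: 2 of 3 stereo elements differ; a stereocentre at a saturated ring carbon is drawn R in compound 1 and S in compound 4; a stereocentre at a saturated ring carbon is drawn S in compound 1 and R in compound 4. The measured steps bear directly on this change, yet their size cannot be read, because every end sits at the limit (the limit of > 12 h in this assay, at which 3 of the 3 values shown sit); what they show is that three configurations all reach the limit. No step beyond the scatter is expected in this assay, in either direction. Compound 4 is expected to give 15 h, within a range from 7 h to 30 h. The estimated step that the limit leaves unreadable from compound 1 to compound 4 is expected to stay inside the scatter, most likely with the assay again reporting only its limit.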

Compound 4, half-life: > 12 h
Compound 4: no number, only a limit; the forecaster's own chance of this, stated with the estimate: 80%; the middle value is on the limit's open side.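

Compound 4 gives only a limit in this assay, > 12 h. No new step can be read from compounds 1, 2 or 3 to compound 4: the limit of > 12 h in this assay, at which 4 of the 4 values shown sit.

The compounds shown leave open how long any of these four configurations actually lasts in this assay, and whether configuration makes any difference to it.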